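A few compounds are considered here, and "the series" means these few. Any claim that something is new, unique, unknown or untested is made for them only; others in the source may bear on it.

Measured so far:
- compound 1 `COc1ccc(-c2nc(C)c(C(=O)CSc3nc(-c4ccc(Cl)cc4)c(C#N)c(=O)[nH]3)s2)cc1`: 2.85%
- compound 2 `COc1ccc(-c2nc(C)c(C(=O)CSc3nc(-c4cccc(OC)c4)c(C#N)c(=O)[nH]3)s2)cc1`: 12.4%
- compound 3 `COc1ccc(-c2nc(C)c(C(=O)CSc3nc(-c4ccc(Cl)c(Cl)c4)c(C#N)c(=O)[nH]3)s2)cc1`: 31.1%

In a functional assay on U-87MG ATCC cells for antiproliferative activity against U-87 MG (Homo sapiens), read by MTT assay, with a stated time of 48 h, tested at 100 uM (a lower number here means a stronger effect, a higher number a weaker effect of the compound at the concentration tested), compound 2 sits second highest of the three numbers; the nearer gap is a number 9.6 percentage points higher from compound 1 to compound 2 (within the scatter), while the further one is a number 18.7 percentage points higher from compound 2 to compound 3 (beyond the scatter). Compound 1 and compound 3 differ by a number 28.3 percentage points higher from compound 1 to compound 3 (beyond the scatter).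

Compound 4 `COc1cccc(-c2nc(SCC(=O)c3sc(-c4ccc(Cl)cc4)nc3C)[nH]c(=O)c2C#N)c1` is not yet measured. It differs from compound 2 by chloro in place of methoxy on an aromatic carbon, that is, on a six-membered aromatic ring of carbon only, para to a large group; cut one bond further out, the change reads 4-methoxyphenyl to 4-chlorophenyl. Going by the values given here, the only measured step that sets chloro against methoxy is a number 9.6 percentage points higher from compound 1 to compound 2 (within the scatter), where a methoxy-bearing ring replaced a chloro-bearing ring on a different part of the shared core and the number stayed within the scatter. Read in reverse, that suggests a small move, if any, toward lower numbers for compound 4. The step from compound 2 to compound 4 is therefore expected to be a number 4.4 percentage points lower from compound 2 to compound 4 (within the scatter). For compound 4 the expected value in this assay is 8%, with a range from 2% to 25%.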

Compound 4, a percentage reported as activity, at one concentration (the size of the read-out at that concentration, not a potency): 8.54%
Estimate against measurement, compound 4: 0.5 percentage points below; the measured number falls inside the stated range.
By their numbers in this assay, from the lowest: compounds 1, 4 and 2 (each within the scatter of the next); then compound 3.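

In this assay, compound 1, compound 2 and compound 3 all carry the 4-methoxyphenyl group, so they say nothing about this position, on a six-membered aromatic ring of carbon only and para to a large group. The change from 4-methoxyphenyl to 4-chlorophenyl gives a number 3.9 percentage points lower from compound 2 to compound 4 (within the scatter), so with 3-methoxyphenyl held constant elsewhere on the shared core, chloro and methoxy cannot be told apart here at the single concentration tested. No measurement on hand bears on why the two groups read alike.

From the compounds shown here alone, whether the same change stays within the scatter with 4-chlorophenyl or 3,4-dichlorophenyl elsewhere on the core remains open. So does the outcome at this position for an amine or a carboxylic acid.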